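The compounds below may be only part of what the source reports. "The series", "measured", "known", "first", "only" and "open" are said of these compounds alone.

Measured compounds:
- compound 1, `Cc1c(C)c2ccc(OCC(=O)NN)cc2oc1=O`, 484 nM
- compound 2, `Cc1cc(=O)oc2cc(OCc3nnc(S)s3)ccc12`, 896 nM

In an assay for inhibition of Amine oxidase [flavin-containing] B (Bos taurus), read by fluorescence, with a stated time of 30 min (on this read-out lower numbers stand for stronger inhibition and higher numbers for weaker inhibition), compound 2 gives 896 nM, the higher of the two numbers recorded so far. Going by the values given here, its only neighbour is compound 1, which in this assay gives 484 nM; the gap between these two values lies within the usual scatter, so the two compounds cannot be told apart on these numbers. Compound 1 and compound 2 also differ in more than one place, so no single step can be read off between them.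

Compound 3, `Cc1c(C)c2ccc(OCc3nnc(S)s3)cc2oc1=O`, has not yet been measured. It is built from compound 2 by one change: methyl in place of hydrogen on an aromatic carbon. Among the compounds with values here, with no measured step of this kind to draw on, the expectation is for no change beyond the scatter, so the estimated step is a 1.2-fold lower number from compound 2 to compound 3 (0.08 log units; within the scatter). Compound 3 is therefore expected to give about 750 nM in this assay, within a range of 300 nM to 1800 nM.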

Compound 3, inhibition constant: 572 nM
The estimate for compound 3 lay 1.3-fold (0.12 log units) above the measured number, and the stated range covers the measured number.
By their numbers in this assay, from the lowest: compounds 1, 3 and 2 (each within the scatter of the next).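

In this assay methyl in place of hydrogen on this aromatic carbon, two atoms from the ring oxygen, gives a 1.6-fold lower number from compound 2 to compound 3 (0.19 log units; within the scatter) and so leaves no change that can be told from the scatter. The new compound also links the two earlier compounds, which differ in more than one place: with both methyl groups present, 5-sulfanyl-1,3,4-thiadiazol-2-yl in place of aminocarbamoyl gives a 1.2-fold higher number from compound 1 to compound 3 (0.07 log units; within the scatter) and so these two groups cannot be told apart here either. Nothing measured here bears on why these steps are small.

Still open, from the compounds shown here alone, is whether a longer chain such as ethyl at this position would move the number beyond the scatter. Going by these compounds, it is also open whether an amine or a carboxylic acid in place of either of the two end groups would do so.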